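Bromo removal in the allyloxy compound of the series

The source may report more compounds than this note shows. Statements on the series, on what has been measured and on what is new or still open speak of the compounds shown alone.

Measured values:
- compound 1 `C=CCOc1cc(Br)ccc1C(=O)c1cccnc1` gives 98000 nM
- compound 2 `O=C(c1cccnc1)c1cc(F)ccc1O` gives 6210 nM
- compound 3 `O=C(c1cccnc1)c1cc(Cl)cc(Cl)c1O` gives 28800 nM

All three numbers come from a functional assay on IMR-32 cells (Homo sapiens) for cytotoxicity, read by sulforhodamine B assay, with a stated time of 48 h (on this read-out lower numbers stand for stronger inhibition and higher numbers for weaker inhibition), and are read on the same scale. Compound 1 has the highest number of the three, and its gaps to compound 3 and compound 2 both lie beyond the scatter. Its activity is therefore the weakest of this small set.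

Compound 4 `C=CCOc1ccccc1C(=O)c1cccnc1` has not yet been measured. Its difference from compound 1 is hydrogen in place of bromo on an aromatic carbon in words, hydrogen in place of bromo on an aromatic carbon. The allyloxy group stays in place.

Among the measured compounds shown here, no measured pair differs in one place only, so the series offers no direct guide to this step. For the measured compounds named here, compound 1 at 98000 nM is the only measured compound with the allyloxy group, which anchors the expectation close to it. In this assay a small shift towards a lower number is expected, probably none beyond the scatter. The estimated change is a 1.6-fold lower number from compound 1 to compound 4 (0.21 log units; within the scatter) in size. The estimated value for compound 4 is 60000 nM with an expected range from 20000 nM to 150000 nM for the coming measurement.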

Compound 4, half-maximal inhibitory concentration: 44000 nM
For compound 4 the middle estimate is 1.4-fold (0.13 log units) above the measured one; low and high end bracket the measured number.
By their numbers in this assay, from the lowest: compound 2; then compounds 3 and 4 (each within the scatter of the next); then compound 1.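

In this assay, among the compounds shown here, the step of a 2.2-fold lower number from compound 1 to compound 4 (0.35 log units; beyond the scatter) is the first change that can be read in one place only, and it lies just beyond the usual scatter. At this position, on an aromatic carbon meta to an allyloxy group and para to a group of 8 heavy atoms, the bromo is therefore not needed for the activity of the allyloxy compound, and hydrogen gives the modestly lower number. No measurement at hand accounts for this step.

Bromo and hydrogen are the only two groups compared at this position, so it remains open whether a methoxy group or an amine there would move the number further in either direction. Compounds 2 and 3 differ from compound 4 in more than one place, so the steps to them cannot be read, and the contribution of the allyloxy group, relative to a hydroxyl or a longer chain on the same oxygen, remains unresolved.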